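Triazole-linked series: trifluoromethyl to methoxy on the aryl

The compounds below may be only part of what the source reports. "The series", "measured", "known", "first", "only" and "open" are said of these compounds alone.

Measured so far in a functional assay on A549 cells (Homo sapiens) for cytotoxicity, read by MTT assay, with a stated time of 4 days; on this read-out lower numbers stand for stronger inhibition and higher numbers for weaker inhibition:
- compound 1 `C=C1C(=O)[C@]23C[C@@]1(O)CC[C@H]2c1ccc(O)c(C)c1[C@@H]3Cn1cc(-c2ccc(C(F)(F)F)cc2)nn1`: 1110 nM
- compound 2 `C=C1C[C@]23C[C@@]1(O)CC[C@@H]2c1cccc(C)c1[C@@H]3Cn1cc(-c2ccccc2)nn1`: > 20000 nM
- compound 3 `C=C1C[C@]23C[C@@]1(O)CC[C@H]2c1ccc(O)c(C)c1[C@@H]3Cn1cc(-c2ccc(C(F)(F)F)cc2)nn1`: 10400 nM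

Compound 1 gives the lowest number of the two numbers that exist in this assay. Compound 3 sits at a higher number, and the gap between compound 1 and compound 3 lies beyond the scatter. For compound 2 this assay reports only a limit, (the limit of > 20000 nM in this assay, at which 1 of the 3 values shown sits), and no number.

Compound 4 `C=C1C(=O)[C@]23C[C@@]1(O)CC[C@H]2c1ccc(O)c(C)c1[C@@H]3Cn1cc(-c2ccc(OC)cc2)nn1` keeps the shared core of compound 1 unchanged and differs only in the group carried on the aryl: methoxy in place of trifluoromethyl on an aromatic carbon. The change leaves the attachment point of the aryl as it is, and the triazole link, the hydroxyl and the carbonyl of the core are untouched. Among the compounds with values here, no measured step touches this position, so the size of the effect has to be guessed from the one value of compound 1 alone.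

Compound 4 is expected to stay close to compound 1 in this assay, with a step of a 1.4-fold higher number from compound 1 to compound 4 (0.13 log units; within the scatter), that is, no change beyond the scatter is expected. The estimate for compound 4 is 1500 nM, with a range from 500 nM to 5000 nM.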

Compound 4, half-maximal inhibitory concentration: 1250 nM
The estimate for compound 4 lay 1.2-fold (0.08 log units) above the measured number; measured number inside the range.
By their numbers in this assay, from the lowest: compounds 1 and 4 (each within the scatter of the next); then compound 3. At a limit, above all of these: compound 2.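

In this assay, within the data shown here, methoxy in place of trifluoromethyl on this aromatic carbon gives a 1.1-fold higher number from compound 1 to compound 4 (0.05 log units; within the scatter) and so is the first measured step at this position; the 4-(trifluoromethyl)phenyl and 4-methoxyphenyl groups cannot be told apart on the shared core of compound 1. The two groups differ in their heavy atoms and in their hydrogen-bond acceptors as counted, yet this read-out does not separate them, which holds for this one pair only and is no rule for the position. Nothing on record bears on why the two groups read alike.

Still open, going by these compounds, is whether a group of another kind on this aromatic carbon, such as an amine, a carboxylic acid or a longer alkoxy chain, would also leave the read-out of compound 1 in place, or whether the tolerance seen here stops with these two groups. Also open, on these data alone, is whether methoxy would behave the same way on the core of compound 3, which carries no carbonyl and so offers a second setting in which this exchange could be read.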